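A few compounds are considered here, and "the series" means these few. Any claim that something is new, unique, unknown or untested is made for them only; others in the source may bear on it.

For the measured compounds named here, compound 1 `COc1cc(F)ccc1-c1ccnc2[nH]c(C3CCN(CC(=O)N(C)C)CC3)cc12` is one of three compounds measured in an ADME assay on microsomes from liver (Homo sapiens) for metabolic stability; a lower number here means slower removal, a higher number faster removal of the compound. In this assay, going by the values given here, compound 1 gives 14 uL/min, the only plain number among the three. Compound 2 `COc1cc(F)ccc1-c1ccnc2[nH]c(C3CCN(C(C)=O)CC3)cc12` gives < 3 uL/min, which is a limit of the assay rather than a number. Compound 3 `COc1cc(C(=O)N2CCCC2)ccc1-c1ccnc2[nH]c(C3CCNCC3)cc12` likewise gives < 3 uL/min, also a limit. Among the compounds with values here, the only step between two compounds that differ in one place is an at least 4.6-fold lower number from compound 1 to compound 2 (0.66 log units; beyond the scatter), and its lower end is set by the limit of < 3 uL/min in this assay, at which 2 of the 3 values shown sit.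

Compound 4 `CCn1cc(-c2ccnc3[nH]c(C4CCN(CC(=O)N(C)C)CC4)cc23)ccc1=O` differs from compound 1 as follows: a group of 9 heavy atoms (7 carbon, 1 nitrogen, 1 oxygen; one six-membered aromatic ring with 1 hetero atom) in place of a group of 9 heavy atoms (7 carbon, 1 oxygen, 1 fluorine; one six-membered aromatic ring of carbon only), on an aromatic carbon. The measured step concerns a different part of the shared core, so it does not bear directly on this change. The expected step is therefore a 1.3-fold lower number from compound 1 to compound 4 (0.10 log units; within the scatter), within the usual scatter. Compound 4 is estimated at 11 uL/min, between 4 uL/min and 28 uL/min.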

Compound 4, intrinsic clearance in a liver preparation (reported as CLH), per the amount of preparation that the assay uses: < 3 uL/min
Compound 4: a limit, no number; the forecaster's own chance of this, stated with the estimate: 15%; middle value at least 3.6-fold (0.56 log units) from the limit.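

The earlier step concerned the group on the amine nitrogen, whereas this one shows that the group on the aromatic carbon opposite the ring nitrogen also matters in this assay: a six-membered aromatic ring with 1 hetero atom in place of 4-fluoro-2-methoxyphenyl gives an at least 4.6-fold lower number from compound 1 to compound 4 (0.66 log units; beyond the scatter). Compound 4 gives < 3 uL/min, which is a limit of the assay and not a number. The full size of this step remains unknown because its end is set by that limit: the limit of < 3 uL/min in this assay, at which 3 of the 4 values shown sit.

From the compounds shown here alone, how a plain phenyl ring, or a phenyl ring carrying an amine, would read at this position remains open.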